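The source may report more compounds than this note shows. Statements on the series, on what has been measured and on what is new or still open speak of the compounds shown alone.

In an ADME assay on MT4 cells (Homo sapiens) for activation, read by MTT assay (a lower number here means that less compound is tolerated, a higher number that more compound is tolerated), compound 1 (`CCC(C)Sc1nc(Cc2c(F)cccc2Cl)c(C)c(=O)[nH]1`) gives > 73000 nM, which is a limit of the assay and not a number. Compound 2 (`CCCCSc1nc(Cc2c(F)cccc2Cl)c(C)c(=O)[nH]1`) gives > 73000 nM, and this too is a limit. For the measured compounds named here, compound 2 therefore has no exact value, and the series so far stands at the limit of > 73000 nM in this assay, at which 2 of the 2 values shown sit.

The next structure is compound 3 (`CCCCSc1nc(C(CC)c2c(F)cccc2Cl)c(C)c(=O)[nH]1`). The change is ethyl in place of hydrogen on a saturated chain carbon bound to two aromatic carbons.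

Going by the values given here, the only measured step is a step that the two limits leave unreadable from compound 1 to compound 2. That step concerns the group on the sulfur rather than the saturated chain carbon, and it gives no size to carry over. Among the compounds with values here, no measured step tests the new ethyl group, so the expectation for this assay is weakly founded. No shift beyond the usual scatter is expected, and another report as a limit is quite likely.

The expected change is an at least 1.2-fold lower number from compound 2 to compound 3 (0.08 log units; that floor lies within the scatter). For compound 3 the estimated value is 60000 nM, with an expected range of 25000 nM to 110000 nM.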

Compound 3, half-maximal cytotoxic concentration: > 3000 nM
Compound 3: a limit, no number (the forecaster's own chance of this, stated with the estimate: 65%); the middle value does not contradict the limit.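

In this assay, for the compounds shown here, compound 2 and compound 3 are both reported only as limits, so no step between them can be read. The compounds shown leave open whether ethyl in place of hydrogen on a saturated chain carbon bound to two aromatic carbons shifts the tolerated concentration at all, and where the exact values of compound 1, compound 2 and compound 3 lie.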